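Notes on Removing One Methoxy from Compound 1

The source may hold more compounds than are shown below. What is called first, only, known or untested is meant among the compounds shown, and "the series" means these compounds.

Measured compounds:
compound 1, `COc1ccc(/C=C2\C(=O)N(c3c(Cl)cccc3Cl)c3ccccc32)cc1OC`: > 100 ug/mL
compound 2, `Cc1ccc2nc(Cl)c(/C=C3\C(=O)N(c4c(Cl)cccc4Cl)c4ccccc43)cc2c1C`: 98 ug/mL

In a functional assay on L132 cells (Homo sapiens) for cytotoxicity, read by MTT assay, with a stated time of 72 h (a higher number here means that more compound is needed for the effect, a lower number that less compound is needed), compound 1 gives > 100 ug/mL, which is a limit of the assay rather than a number. Compound 2 gives 98 ug/mL in this assay. Compound 1 therefore stands at the limit of > 100 ug/mL in this assay, at which 1 of the 2 values shown sits; the two values shown say nothing about a step between them.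

Compound 3, `COc1ccc(/C=C2\C(=O)N(c3c(Cl)cccc3Cl)c3ccccc32)cc1`, differs from compound 1 by hydrogen in place of methoxy on an aromatic carbon. Going by the values given here, no step between measured compounds is available to size this change. The expectation is no step beyond the usual scatter in this assay, with the result most likely again reported as a limit.

Compound 3 is expected near 110 ug/mL, with a range from 50 ug/mL to 250 ug/mL. This estimate means an expected step that the limit leaves unreadable from compound 1 to compound 3, within the scatter.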

Compound 3, concentration for half-maximal effect: > 100 ug/mL
Compound 3 ended at the assay's limit (the forecaster's own chance of this, stated with the estimate: 60%); the middle value lies beyond the limit too.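

Compound 1 and compound 3 both stand at a limit rather than a number in this assay, so no step between them can be read: the limit of > 100 ug/mL in this assay, at which 2 of the 3 values shown sit.

Going by these compounds, whether hydrogen in place of methoxy on an aromatic carbon shifts the result in this assay at all remains open.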